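The source may report more compounds than this note shows. Statements on the series, on what has been measured and on what is new or still open speak of the compounds shown alone.

In a functional assay on L1210 cells (Mus musculus) (on this read-out lower numbers stand for an effect already at smaller amounts and higher numbers for an effect only at larger amounts of compound), compound 1 `Nc1ncn(C[C@@H]2CO[C@H](CO)O2)c(=O)n1` gives 70000 nM and compound 2 `Nc1ncn(C[C@H]2CO[C@@H](CO)O2)c(=O)n1` gives 90000 nM with the two level on these numbers. Compound 3 `Nc1ncn(C[C@@H]2CO[C@@H](CO)O2)c(=O)n1` departs from compound 2 as follows: the two compounds have the same atoms and bonds and differ only in configuration as drawn: 1 of 2 stereo elements differ; a stereocentre at a saturated ring carbon is drawn S in compound 2 and R in compound 3 and nothing else changes. For the measured compounds named here, the one measured step bearing on this is a 1.3-fold higher number from compound 1 to compound 2 (0.11 log units; within the scatter) and it inverts both stereocentres, whereas compound 3 inverts one. Because that step stays at a 1.3-fold higher number from compound 1 to compound 2 (0.11 log units; within the scatter) no change beyond the scatter is expected in this assay although this single step is weak guidance. The estimated step is a 1.3-fold lower number from compound 2 to compound 3 (0.11 log units; within the scatter) in this read-out. Compound 3 is expected at 70000 nM with an estimated range from 25000 nM to 200000 nM in this assay when measured.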

Compound 3, half-maximal effective concentration: 80000 nM
Compound 3: the middle estimate sits 1.1-fold (0.06 log units) below what was measured, and the stated range covers the measured number.
By their numbers in this assay, from the lowest: compounds 1, 3 and 2 (each within the scatter of the next).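

Compound 3 shows what inverting a single stereocentre does, where the earlier pair showed only both inverted together. In this assay, one such inversion gives a 1.1-fold lower number from compound 2 to compound 3 (0.05 log units; within the scatter) and the other gives a 1.1-fold higher number from compound 1 to compound 3 (0.06 log units; within the scatter). Each stereocentre has thus been changed alone, and neither change moves the number beyond the scatter, just as inverting both did not.

Going by these compounds, all three compounds share the same atoms and bonds, so the fourth possible arrangement of these two stereocentres remains open. So does the effect of changing a group itself, for instance an amine, a carboxylic acid or a longer chain on the shared core.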